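Series notes: compound 4 set against the three measured compounds

A few compounds are considered here, and "the series" means these few. Any claim that something is new, unique, unknown or untested is made for them only; others in the source may bear on it.

Compound 3 `N=C(S)CCCCCn1nc(-c2ccccc2)ccc1=O` stands highest of the three measured in a functional assay on the whole organism (stomach) for inhibition, with Rattus norvegicus as the target, at a dose of 100 mg/kg by the intraduodenal route (on this read-out higher numbers stand for more inhibition at the one dose given (going by the name of the read-out) and lower numbers for less inhibition), where compound 3 gives 91.4%. Compound 1 `N#CCCn1nc(-c2ccccc2)ccc1=O` gives 10.1% and compound 2 `CC(CC(=N)S)n1nc(-c2ccccc2)ccc1=O` gives 15.5%; the step of a number 5.4 percentage points higher from compound 1 to compound 2 (within the scatter) stays within the scatter, whereas a number 81.3 percentage points higher from compound 1 to compound 3 (beyond the scatter) is a large step well beyond it. Compound 4 `O=C(O)CCn1nc(-c2ccccc2)ccc1=O` differs from compound 3 in a single place: a group of 3 heavy atoms (1 carbon, 2 oxygen; no ring) in place of a group of 6 heavy atoms (4 carbon, 1 nitrogen, 1 sulfur; no ring), on a saturated chain carbon, two bonds along the chain from an aromatic nitrogen. For the measured compounds named here, only one measured step bears on this change, namely a number 81.3 percentage points higher from compound 1 to compound 3 (beyond the scatter), in which the very group of 6 heavy atoms that compound 4 now loses was the group that entered at that same chain carbon and carried the whole rise. Carboxy, a group of 3 heavy atoms, is closer in size to the group of 2 heavy atoms in compound 1 than to what it replaces. A large downward step is therefore expected, a number 76.4 percentage points lower from compound 3 to compound 4 (beyond the scatter). Compound 4 is estimated at 15%, with a range from 0% to 45%.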

Compound 4, a percentage reported as inhibition, in the whole organism at one dose (the size of the read-out at that dose, not a potency): 26.1%
For compound 4 the middle estimate is 11.1 percentage points below the measured one; the measured number falls inside the stated range.
By their numbers in this assay, from the lowest: compounds 1 and 2 (each within the scatter of the next); then compound 4; then compound 3.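

At the saturated chain carbon, two bonds along the chain from an aromatic nitrogen, carboxy does not hold the level of compound 3, giving a number 65.3 percentage points lower from compound 3 to compound 4 (beyond the scatter). Carboxy in place of cyano gives only a number 16 percentage points higher from compound 1 to compound 4 (beyond the scatter), and the change on the aromatic nitrogen gives a number 10.6 percentage points higher from compound 2 to compound 4 (beyond the scatter), so a second small group at this place now shows a modest gain, while the high number remains confined to compound 3 among the four. No information accompanies these numbers that would account for the differences between the groups.

Still open, going by these compounds, is whether carboxy on a longer chain would stay low, which would show whether the chain or its end group matters more in the group of 6 heavy atoms. An amine or an amide at this chain carbon could also help separate the two.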